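Shortening an ether chain on a shared biaryl acid core

A few compounds are considered here, and "the series" means these few. Any claim that something is new, unique, unknown or untested is made for them only; others in the source may bear on it.

Four compounds share one core and differ only in the group carried on an oxygen on an aromatic ring. Compound 1 `Cc1cc(OCC(C)C)cc(C)c1-c1cccc(COc2ccc(OCC(=O)O)c(F)c2)c1` and compound 2 `Cc1cc(OC(C)C)cc(C)c1-c1cccc(COc2ccc(OCC(=O)O)c(F)c2)c1` have no result in a physicochemical assay for lipophilicity, using the shake flask method, in phosphate buffer, measured as octanol-water partition, with a stated time of 24 h, at pH 7.4, tested at 100 uM; a higher number here means a more lipophilic compound, a lower number a more polar compound: compound 1 stands at "not determined" (no result reported) and compound 2 stands at "not determined" (no result reported). Only compound 3 `Cc1cc(OCCCS(C)(=O)=O)cc(C)c1-c1cccc(COc2ccc(OCC(=O)O)c(F)c2)c1` has a number, and in this assay compound 3 gives 1.81. Going by the values given here, compound 2 therefore cannot be placed on the scale at all; the single measured point is compound 3.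

The step from compound 2 to compound 4 `COc1cc(C)c(-c2cccc(COc3ccc(OCC(=O)O)c(F)c3)c2)c(C)c1` is this: methyl in place of isopropyl on an oxygen on an aromatic ring. Nothing measured tells how this change moves this assay, so the expectation rests on compound 3 alone, which carries a longer chain than compound 4 on the same oxygen. Compound 4 is expected to sit higher than compound 3, by a clear margin beyond the usual scatter, though with wide uncertainty. Compound 4 is estimated at 3.3, within a range of 2.6 to 4.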

Compound 4, distribution coefficient: 3.2
Compound 4: middle estimate off by 0.10 log units, on the high side; measured number inside the range.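

This position is not neutral: with this assay, the group on this oxygen can shift the reading strongly. Going by these compounds alone, replacing the 2-(methylsulfonyl)ethyl part of the chain with hydrogen, which leaves a bare methyl on the oxygen, gives a number 1.39 log units higher from compound 3 to compound 4 (beyond the scatter), the first measured step in this set. No supporting data bear on why the number moves this far.

The isopropyl to methyl step itself cannot be read, since compound 2 has no number, and the same holds for any step involving compound 1. Within the data shown here, two changes also travel together in the one readable step, chain length and the sulfonyl group, so a plain propyl chain or a chain ending in an amine on the same oxygen would be needed to pull them apart.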